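A few compounds are considered here, and "the series" means these few. Any claim that something is new, unique, unknown or untested is made for them only; others in the source may bear on it.

Values measured in a physicochemical assay for lipophilicity, measured as octanol-water partition, at pH 7.4; a higher number here means a more lipophilic compound, a lower number a more polar compound:

- Compound 1 `CC(C)(C)c1ccc(NC(=N)Nc2ccc(C(C)(C)C)cc2)cc1`: 3.65
- Compound 2 `CCCCOc1ccc(NC(=N)Nc2ccc(OCCCC)cc2)cc1`: 3.52

Compound 2, at 3.52, stands level with compound 1, at 3.65, as the two values lie within the usual scatter of each other. The two compounds differ in more than one place, so their values give no measure of any single structural change.

Compound 3 `CCCCOc1ccc(NC(=N)Nc2ccc(CCCCO)cc2)cc1` has the same atoms as compound 2, joined differently, with 4-hydroxybutyl in place of butoxy on an aromatic carbon. The entering group and the leaving group match in the count of heavy atoms and differ in the count of hydrogen-bond donors.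

Going by the values given here, no measured pair shows this exchange, so the expectation rests on the structural change alone. A clear fall in this assay, beyond the scatter, is expected. The estimated size of this fall is a number 0.92 log units lower from compound 2 to compound 3 (beyond the scatter). For compound 3 the expected value is 2.6, with an estimated range of 2.1 to 3.1.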

Compound 3, distribution coefficient: 1.72
The estimate for compound 3 lay 0.88 log units above the measured number; measured number outside the range, below it.
By their numbers in this assay, from the lowest: compound 3; then compounds 2 and 1 (each within the scatter of the next).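

Among the compounds shown, this is the first change in a single place that can be read: with 4-hydroxybutyl in place of butoxy on an aromatic carbon, para to a large group, this assay gives a number 1.80 log units lower from compound 2 to compound 3 (beyond the scatter) even though the two compounds have the same atoms, joined differently. The entering and leaving groups match in their count of heavy atoms and in their hydrogen-bond acceptors but differ in their hydrogen-bond donors, so the step shows that, at this position, a matching heavy-atom count does not ensure a similar value. Nothing available accounts for the size of this step.

The compounds shown leave open whether 4-methoxybutyl, with a methyl group on the chain oxygen, would give a value in this assay near that of compound 2 or near that of compound 3, and how a 4-aminobutyl chain or a carboxylic acid on the same chain would compare. They also leave open whether the same exchange on the remaining butoxy group would produce a step of similar size.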